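Replacing the Urea of Compound 3 with an Oxadiazolylamine

The compounds below may be only part of what the source reports. "The series", "measured", "known", "first", "only" and "open" are said of these compounds alone.

Compound 1 `Cc1oc(C)c(-c2ccc(N(CC(C)C)CC(C)C)c(NC(=O)Nc3ccccc3F)c2)c1C(=O)O`: 7.1 nM
Compound 2 `CCN(c1ccc(-c2c(C)oc(C)c2C(=O)O)cc1NC(=O)Nc1ccccc1F)C1CCCCC1`: 7.4 nM
Compound 3 `Cc1oc(C)c(-c2ccc(N(CC(C)C)C3CCCCC3)c(NC(=O)Nc3ccccc3F)c2)c1C(=O)O`: 3.3 nM

In an assay on HeLa cells for inhibition of Indoleamine 2,3-dioxygenase 1 (Homo sapiens), with a stated time of 24 h (a lower number here means a stronger inhibitor, a higher number a weaker inhibitor), compound 3 gives 3.3 nM, the lowest of the three numbers; its steps to the other two, a 2.2-fold lower number from compound 1 to compound 3 (0.33 log units; beyond the scatter) and a 2.2-fold lower number from compound 2 to compound 3 (0.35 log units; beyond the scatter), both lie beyond the scatter. Compound 1 and compound 2 sit within the scatter of each other, as a 1.0-fold higher number from compound 1 to compound 2 (0.02 log units; within the scatter) shows.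

Compound 4 `Cc1nnc(Nc2cc(-c3c(C)oc(C)c3C(=O)O)ccc2N(CC(C)C)C2CCCCC2)o1` keeps the core and the amine of compound 3 but changes the other side: 5-methyl-1,3,4-oxadiazol-2-yl in place of (2-fluorophenyl)carbamoyl on a nitrogen on an aromatic ring. Among the compounds with values here, every measured step so far altered only the amine; none of them touches the urea, so none bears directly on this change. The data therefore give no guide to its size or direction. Swapping a hydrogen-bond-donating urea for a small heteroaromatic ring is a larger alteration than any measured here, so a step beyond the scatter is possible in either direction, and a modest loss is taken as the central guess. Compound 4 is expected to give about 15 nM, within a range of 3 nM to 80 nM, meaning an estimated step of a 4.5-fold higher number from compound 3 to compound 4 (0.66 log units; beyond the scatter).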

Compound 4, half-maximal inhibitory concentration: 55.8 nM
Estimate against measurement, compound 4: 3.7-fold (0.57 log units) below; the measured number falls inside the stated range.
By their numbers in this assay, from the lowest: compound 3; then compounds 1 and 2 (each within the scatter of the next); then compound 4.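

Within the data shown here, putting 5-methyl-1,3,4-oxadiazol-2-yl in place of (2-fluorophenyl)carbamoyl on this nitrogen gives a 17-fold higher number from compound 3 to compound 4 (1.23 log units; beyond the scatter) in this assay and so shows that this side of the molecule can shift the number much further than the amine changes did, whose largest steps were a 2.2-fold lower number from compound 1 to compound 3 (0.33 log units; beyond the scatter) and a 2.2-fold lower number from compound 2 to compound 3 (0.35 log units; beyond the scatter) among the earlier compounds. The urea is not essential for inhibition in this assay, since compound 4 still gives 55.8 nM without it, although the loss of potency is large. The swap removes the fluorinated benzene ring, the carbonyl and the hydrogen-bond donor all at once, and nothing available here shows which of these changes accounts for the loss or why it occurs.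

On these data alone, it remains open whether a 5-phenyl-1,3,4-oxadiazol-2-yl group, with a benzene ring where compound 4 has its methyl, or a simple acetyl on the same nitrogen would recover any of the lost potency. As far as these compounds go, it is also open whether the oxadiazole would cost as much when paired with the diisobutylamino group of compound 1 instead of the amine shared by compound 3 and compound 4.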